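The source may report more compounds than this note shows. Statements on the series, on what has been measured and on what is new or still open speak of the compounds shown alone.

For the measured compounds named here, compound 2 `CC(C)CCc1sc(NC(=O)c2cc(NC(=O)c3cc(NC(=N)c4ccc(F)cc4)cn3C)cn2C)nc1C(=O)NCCCN(C)C` stands highest of the two numbers so far in an assay on nucleic acid for binding affinity to Salmon testes DNA (Salmonidae), tested at 10 uM (on this read-out lower numbers stand for weaker stabilisation of the target and higher numbers for stronger stabilisation of the target against heat), with compound 2 giving 9 degrees C. Compound 1 `CC(C)CCc1sc(NC(=O)c2cc(NC(=O)c3cc(NC(=N)c4cccc(F)c4)cn3C)cn2C)nc1C(=O)NCCCN(C)C` gives 4 degrees C in this assay, and a number 5.0 degrees C higher from compound 1 to compound 2 (beyond the scatter). Compound 3 `CC(C)CCc1sc(NC(=O)c2cc(NC(=O)c3cc(NC(=N)c4ccccc4)cn3C)cn2C)nc1C(=O)NCCCN(C)C` carries hydrogen in place of fluoro on an aromatic carbon. Going by the values given here, no measured step removes the fluorine outright; the only step touching this group moved the shift by a large amount through position alone, so a moderate drop is expected, a number 3.0 degrees C lower from compound 2 to compound 3 (beyond the scatter). Compound 3 is therefore estimated at 6 degrees C, within 3 degrees C to 10 degrees C.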

Compound 3, shift of the target's melting temperature: 7 degrees C
The estimate for compound 3 lay 1.0 degrees C below the measured number; the range from low to high includes it.
By their numbers in this assay, from the lowest: compound 1; then compound 3; then compound 2.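

In this assay the unsubstituted phenyl gives both fluoro compounds a common reference: hydrogen in place of fluoro gives a number 2.0 degrees C lower from compound 2 to compound 3 (beyond the scatter) and, in the opposite direction, a number 3.0 degrees C higher from compound 1 to compound 3 (beyond the scatter) here. Fluorine on this ring is therefore not tied to one direction: the 4-fluorophenyl of compound 2 stands above phenyl, while the differently placed fluorine of compound 1 stands below it. Nothing measured here gives a reason for this.

From the compounds shown here alone, whether chlorine, a methoxy group or an amine, para to a large group, would stand above or below the fluorine of compound 2 stays open.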